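The compounds below may be only part of what the source reports. "The series", "measured", "known", "first", "only" and "open" are said of these compounds alone.

Working notes on the series. Among the compounds with values here, compound 3 `CN(C)CCn1cnnc1-c1cc(Oc2ccc(NC(=O)N/N=C/c3ccc(F)cc3F)cc2F)ccn1` stands with the lowest of the two numbers so far: in a functional assay on U-87MG ATCC cells (Homo sapiens) for cytotoxicity, read by MTT assay, with a stated time of 72 h (a lower number here means a stronger inhibitor, a higher number a weaker inhibitor), compound 3 gives 1900 nM. The nearest is compound 2 `COc1ccc(/C=N/NC(=O)Nc2ccc(Oc3ccnc(-c4nncn4CCN(C)C)c3)c(F)c2)c(OC)c1OC`, for which this assay returns 7650 nM, a step of a 4.0-fold lower number from compound 2 to compound 3 (0.60 log units; beyond the scatter). Compound 1 `CN(C)CCn1cnnc1-c1cc(Oc2ccc(NC(=O)N/N=C/c3ccc(O)c(F)c3)cc2F)ccn1` reaches only a limit of the assay: in this assay compound 1 gives > 100000 nM. That is the limit of > 100000 nM in this assay, at which 1 of the 3 values shown sits. The two steps starting from compound 1 are accordingly limits as well: an at least 13-fold lower number from compound 1 to compound 2 (1.11 log units; beyond the scatter) and an at least 52-fold lower number from compound 1 to compound 3 (1.72 log units; beyond the scatter).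

Compound 4 `COc1cc(/C=N/NC(=O)Nc2ccc(Oc3ccnc(-c4nncn4CCN(C)C)c3)c(F)c2)ccc1O` is still to be measured. The change: 4-hydroxy-3-methoxyphenyl in place of 2,4-difluorophenyl on a carbon with a double bond to nitrogen. Compound 1 bears most on this step because an at least 52-fold lower number from compound 1 to compound 3 (1.72 log units; beyond the scatter) runs between a ring carrying a hydroxy group and the 2,4-difluorophenyl of compound 3, and compound 4 again carries a hydroxy group on that ring. Compound 2, which carries methoxy groups there, also gives a higher number than compound 3, by a 4.0-fold lower number from compound 2 to compound 3 (0.60 log units; beyond the scatter). A large upward step is therefore expected, estimated as a 21-fold higher number from compound 3 to compound 4 (1.32 log units; beyond the scatter). Compound 4 is estimated at 40000 nM, with an expected range from 8000 nM to 200000 nM, and a real chance that only a limit is reported.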

Compound 4, half-maximal inhibitory concentration: > 100000 nM
Compound 4 ended at the assay's limit (the forecaster's own chance of this, stated with the estimate: 40%); middle value at least 2.5-fold (0.39 log units) from the limit.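

With the 4-hydroxy-3-methoxyphenyl group on the carbon with a double bond to nitrogen, compound 4 reaches a limit in this assay, so both readable steps are limits as well: an at least 52-fold higher number from compound 3 to compound 4 (1.72 log units; beyond the scatter) and an at least 13-fold higher number from compound 2 to compound 4 (1.11 log units; beyond the scatter). Among the four compounds shown, the two with a hydroxy group on this ring, compound 1 and compound 4, both end at the limit, while compound 2 and compound 3, which have none, give numbers, and no compound shown goes against this split: the limit of > 100000 nM in this assay, at which 2 of the 4 values shown sit. Methoxy groups on this ring do not by themselves bring a compound to the limit, as compound 2 carries them and still gives a number, while the step between compound 1 and compound 4, methoxy in place of fluoro, cannot be read.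

No pair shown differs only at the hydroxy group, so its own part in the split remains open, and the four compounds cannot establish it as a general pattern. An amino group or a carboxylic acid in place of the hydroxy group on this ring would show whether the split extends beyond the hydroxy group.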